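The source may report more compounds than this note shows. Statements on the series, on what has been measured and on what is new or still open speak of the compounds shown alone.

Measured so far in a functional assay on OVCAR-3 cells (Homo sapiens) for antiproliferative activity, read by MTT assay, with a stated time of 24 h; a lower number here means a stronger inhibitor, a higher number a weaker inhibitor:
compound 1 `O=C(NNc1ccccc1Cl)c1ccc(NS(=O)(=O)c2cnc(O)nc2O)cc1` gives 7230 nM
compound 2 `O=C(NNc1cccc(Cl)c1)c1ccc(NS(=O)(=O)c2cnc(O)nc2O)cc1` gives 8410 nM
compound 3 `CCCCOc1ccc(C(=O)NNC(=O)c2ccc(NS(=O)(=O)c3cnc(O)nc3O)cc2)cc1` gives 12800 nM

Compound 3 at 12800 nM lies within the scatter of both compound 1 and compound 2, so the three values do not separate in this assay here.

The next compound is compound 4 `Cc1ccc(C(=O)NNC(=O)c2ccc(NS(=O)(=O)c3cnc(O)nc3O)cc2)cc1` which carries methyl in place of butoxy on an aromatic carbon, para to a large group. The change in full: methyl in place of butoxy on an aromatic carbon and it is the only difference between the two structures.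

Among the measured compounds shown here, the one measured step is a 1.2-fold higher number from compound 1 to compound 2 (0.07 log units; within the scatter) and it stays within the scatter. It concerns a different group, so it bears on this change only indirectly. For the measured compounds named here, no measured step replaces butoxy or any other group at this position, which leaves the size of this change untested. The expectation rests on compound 3 at 12800 nM and on the small spread among the three measured values.

The expected step is a 1.3-fold lower number from compound 3 to compound 4 (0.11 log units; within the scatter) in this assay and no move beyond the scatter is expected in either direction. The estimate for compound 4 is 10000 nM with an expected range from 4500 nM to 22000 nM as a working guess.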

Compound 4, half-maximal inhibitory concentration: > 20000 nM
Compound 4: no number, only a limit (the forecaster's own chance of this, stated with the estimate: 3%); middle value at least 2.0-fold (0.30 log units) away from the limit.
By their numbers in this assay, from the lowest: compounds 1, 2 and 3 (each within the scatter of the next). At a limit, above all of these: compound 4.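

In this assay compound 4 gives no number, only a limit: the limit of > 20000 nM in this assay, at which 1 of the 4 values shown sits.

From the compounds shown here alone, with methyl in place of butoxy on this aromatic carbon, para to a large group, the result is an at least 1.5-fold higher number from compound 3 to compound 4 (0.19 log units; that floor lies within the scatter), so this floor alone does not set the two compounds apart and the true size of the change remains unknown. The series nevertheless shows its first separation beyond the scatter, with (4-methylphenyl)carbonyl in place of the chlorophenyl groups on the amine nitrogen giving an at least 2.3-fold higher number from compound 2 to compound 4 (0.37 log units; beyond the scatter) and an at least 2.7-fold higher number from compound 1 to compound 4 (0.44 log units; beyond the scatter), whereas the three earlier values all lay within the scatter of one another.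

Open, going by these compounds, is how far compound 4 actually lies from compound 3, since a limit fixes only a floor for that step. Also open, on these data alone, is what an ethoxy group, a longer chain such as hexyloxy, an amine or a carboxylic acid on the same aromatic carbon would give, and whether any of these would return a number in this assay or reach a limit as compound 4 does.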